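Cytotoxicity of proline-type amides in human lung fibroblasts

This account rests on a few compounds, and the source may have more. Where it says the series, first, only, none or still open, it means among the compounds named here.

Measured compounds:
compound 1 `CC(C)C[C@H](NC(=O)[C@]1(Cc2ccccc2)CCN1C(=O)OCc1ccccc1)C(N)=O` – 100000 nM
compound 2 `NC(=O)[C@H](CCC(=O)O)NC(=O)C1(Cc2ccccc2)CCN1C(=O)OCc1ccccc1` – > 100000 nM
compound 3 `C[C@H](NC(=O)[C@@]1(Cc2ccccc2)CCN1C(=O)OCc1ccccc1)C(=O)N(C)C` – > 100000 nM

Three amides built on a shared core were examined in an ADME assay on HELF cells (Homo sapiens) for cytotoxicity, with a stated time of 3 days; on this read-out higher numbers stand for lower toxicity in this test and lower numbers for higher toxicity in this test. Compound 1 is the only one of the three to give a number at all, with 100000 nM. For compound 2 the result is a limit of the test, > 100000 nM. For compound 3 the result is likewise a limit, > 100000 nM. Two of the three results thus sit at the limit, (the limit of > 100000 nM in this assay, at which 2 of the 3 values shown sit), so compound 1 marks the one point where the test reports a value, and that value coincides with the limit itself.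

Compound 4 `C[C@H](NC(=O)[C@]1(Cc2ccccc2)CCN1C(=O)OCc1ccccc1)C(=O)NCc1ccccc1` has not yet been measured in this assay. Relative to compound 1 it carries 1-(benzylcarbamoyl)ethyl in place of 1-carbamoyl-3-methylbutyl on an amide-type nitrogen. Within the data shown here, no step between measured compounds is available to calibrate this change, and with all three results at or beyond the same limit, no direction can be read from the data. Compound 4 is therefore expected to show no step beyond the scatter, no change at the digits printed from compound 1 to compound 4 (within the scatter), with a fair chance that the test again reports only a limit. The estimate for compound 4 is 100000 nM, with a range from 30000 nM to 200000 nM.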

Compound 4, minimum cytotoxic concentration: 100000 nM
Estimate against measurement, compound 4: no gap at the digits printed; the range from low to high includes it.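

In this assay, putting 1-(benzylcarbamoyl)ethyl in place of 1-carbamoyl-3-methylbutyl on an amide-type nitrogen gives no change at the digits printed from compound 1 to compound 4 (within the scatter). Among these compounds, this is the first step that can be read at this place, and it shows that a group with one six-membered aromatic ring of carbon only, taking the place of a group with no ring, gives the same printed value. That reading has little room to show more, as both values stand at the same figure as the limit of the test: the limit of > 100000 nM in this assay, at which 2 of the 4 values shown sit.

Going by these compounds, how an amine or a longer alkyl chain at this place would read in this assay stays open. Also open, on these data alone, is whether any group there gives a lower number in this test.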